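The source may report more compounds than this note shows. Statements on the series, on what has been measured and on what is new or still open speak of the compounds shown alone.

Among the compounds with values here, in a functional assay on K562 cells (Homo sapiens) for inhibition, read by trypan blue exclusion, with a stated time of 72 h (a higher number here means a weaker inhibitor, a lower number a stronger inhibitor), compound 2 `Cn1c(=O)c(S(=O)(=O)c2ccc(F)cc2)cc2cnc(Nc3ccc4[nH]ncc4c3)nc21` gives 10000 nM, the higher of the two numbers so far, while compound 1 `Cn1c(=O)c(S(=O)(=O)c2ccc(F)cc2)cc2cnc(Nc3ccc4[nH]ccc4c3)nc21` gives 200 nM. Unmeasured compound 3 `Cn1c(=O)c(S(=O)(=O)c2ccc(F)cc2)cc2cnc(Nc3ccc4[nH]cnc4c3)nc21` differs from compound 2 by 1H-benzimidazol-5-yl in place of 1H-indazol-5-yl on a nitrogen on an aromatic ring; the two have the same atoms, joined differently. Within the data shown here, the one measured step that bears on this is the large 50-fold higher number from compound 1 to compound 2 (1.70 log units; beyond the scatter), where 1H-indazol-5-yl replaced 1H-indol-5-yl at the same place. Among the measured compounds shown here, no measured compound yet carries 1H-benzimidazol-5-yl, so the direction is uncertain, but a partial return towards compound 1 is expected. The expected change is a 4.0-fold lower number from compound 2 to compound 3 (0.60 log units; beyond the scatter). Compound 3 is estimated at 2500 nM, with an expected range of 400 nM to 15000 nM.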

Compound 3, half-maximal inhibitory concentration: 10000 nM
For compound 3 the middle estimate is 4.0-fold (0.60 log units) below the measured one, within the range that was stated.
By their numbers in this assay, from the lowest: compound 1; then compounds 2 and 3 (each within the scatter of the next).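

In this assay the exchange of 1H-indazol-5-yl for 1H-benzimidazol-5-yl gives no change at the digits printed from compound 2 to compound 3 (within the scatter), so at this place on the nitrogen the two groups cannot be told apart. Within the data shown here, the step of a 50-fold higher number from compound 1 to compound 3 (1.70 log units; beyond the scatter) is the same size as the one printed for 1H-indazol-5-yl, which leaves 1H-indol-5-yl as the only group of the three with the lower number. Nothing measured here explains this gap.

Open, from the compounds shown here alone, is whether 1H-indol-5-yl is needed at all, or whether a simpler phenyl carrying a hydroxyl group would serve at this place. Also open, going by these compounds, is how the gap behaves with a methyl group on the indole nitrogen.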